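A few compounds are considered here, and "the series" means these few. Any claim that something is new, unique, unknown or untested is made for them only; others in the source may bear on it.

In an ADME assay on RAW264.7 cells (Mus musculus) for cytotoxicity, read by MTT assay, with a stated time of 24 h (on this read-out higher numbers stand for lower toxicity in this test and lower numbers for higher toxicity in this test), compound 1 (`CC/C=C\C[C@H]1C(=O)C=C[C@H]1CC(=O)OCCCCC`) gives 37 uM and compound 2 (`CC/C=C\C[C@H]1C(=O)C=C[C@H]1CC(=O)OCc1ccccc1`) gives 31 uM on the shared core. Compound 3 (`CC/C=C\C[C@H]1C(=O)C=C[C@H]1CC(=O)OC(C)C`) gives 58 uM and so stands level with both of them, as a 1.6-fold higher number from compound 1 to compound 3 (0.20 log units; within the scatter) and a 1.9-fold higher number from compound 2 to compound 3 (0.27 log units; within the scatter) show. Compound 4 (`CC/C=C\C[C@H]1C(=O)C=C[C@H]1CC(=O)OC(C)(C)C`) follows from compound 3 by methyl in place of hydrogen on a saturated chain carbon bound to an oxygen next to a carbonyl group and two saturated chain carbons and so turns isopropyl to tert-butyl. All three measured steps bear on this change: those two and a 1.2-fold lower number from compound 1 to compound 2 (0.08 log units; within the scatter) each alter the group on the oxygen next to a carbonyl group, and each stays within the scatter. For this assay the expected change is therefore a 1.3-fold lower number from compound 3 to compound 4 (0.11 log units; within the scatter) and nothing beyond the scatter. Compound 4 is estimated at 45 uM with an expected range from 25 uM to 80 uM here.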

Compound 4, half-maximal toxic concentration: 33 uM
The estimate for compound 4 lay 1.4-fold (0.13 log units) above the measured number; low and high end bracket the measured number.
By their numbers in this assay, from the lowest: compounds 2, 4, 1 and 3 (each within the scatter of the next).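

In this assay, methyl in place of hydrogen on this saturated chain carbon, which turns isopropyl to tert-butyl, gives a 1.8-fold lower number from compound 3 to compound 4 (0.24 log units; within the scatter), so this change at the carbon itself also stays within the scatter. The tert-butyl group also reads level with benzyl and pentyl, as a 1.1-fold higher number from compound 2 to compound 4 (0.03 log units; within the scatter) and a 1.1-fold lower number from compound 1 to compound 4 (0.05 log units; within the scatter) show, so all four groups on this oxygen read alike in this test. Nothing available bears on why these numbers read alike. The compounds shown leave open whether a group on this oxygen carrying an amine or a carboxylic acid would move the number beyond the scatter.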